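Cyclopentyl Ether in Place of the Phenol Hydrogen

The source may hold more compounds than are shown below. What is called first, only, known or untested is meant among the compounds shown, and "the series" means these compounds.

Two compounds share one core and differ at a single aromatic position. Compound 1 `Cc1cc(Sc2cccc(Cl)c2)c(S(C)(=O)=O)cc1C(=O)N=C(N)N` carries a (3-chlorophenyl)sulfanyl group there, and in a functional assay for inhibition of sodium/hydrogen exchanger (Oryctolagus cuniculus) (on this read-out lower numbers stand for stronger inhibition and higher numbers for weaker inhibition), compound 1 gives 37 nM. Compound 2 `Cc1cc(O)c(S(C)(=O)=O)cc1C(=O)N=C(N)N` carries a hydroxy group instead, and in this assay compound 2 gives 220 nM, the higher of the two numbers, so compound 2 is the weaker inhibitor of the pair. The step of a 5.9-fold higher number from compound 1 to compound 2 (0.77 log units; beyond the scatter) shows that swapping the large sulfur-linked group for a small hydroxy weakened inhibition. Compound 3 `Cc1cc(OC2CCCC2)c(S(C)(=O)=O)cc1C(=O)N=C(N)N` keeps the oxygen of compound 2 but has cyclopentyl in place of hydrogen on an oxygen on an aromatic ring. Among the measured compounds shown here, no measured step covers exactly this change; the only step that bears on it is the one just described, which was modest but beyond the scatter. Since compound 1, with a larger group at this position, gave 37 nM, restoring bulk is expected to help. In this assay compound 3 is therefore estimated at 50 nM, within a range from 15 nM to 160 nM, an expected step of a 4.4-fold lower number from compound 2 to compound 3 (0.64 log units; beyond the scatter).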

Compound 3, half-maximal inhibitory concentration: 27 nM
Beside the measured number, compound 3's estimate is 1.9-fold (0.27 log units) above it; low and high end bracket the measured number.
By their numbers in this assay, from the lowest: compounds 3 and 1 (each within the scatter of the next); then compound 2.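

In this assay, putting cyclopentyl on the oxygen brings an 8.1-fold lower number from compound 2 to compound 3 (0.91 log units; beyond the scatter), so inhibition does not depend on keeping the hydrogen of the hydroxy group. Unlike the earlier pair, where the whole sulfur-linked group gave way to hydroxy, this step keeps the oxygen and changes only what sits on it, showing that the weaker inhibition of compound 2 can be recovered with the oxygen still in place. Replacing (3-chlorophenyl)sulfanyl with cyclopentyloxy gives a 1.4-fold lower number from compound 1 to compound 3 (0.14 log units; within the scatter), so these two groups cannot be told apart here, and neither the sulfur link nor the chlorophenyl ring is required. Going by these compounds, whether a methyl or a longer chain on the oxygen, or an amine in place of it, would serve as well remains open. The data offer no explanation for why cyclopentyl restores inhibition.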